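The source may report more compounds than this note shows. Statements on the series, on what has been measured and on what is new or still open speak of the compounds shown alone.

In a functional assay on Jurkat cells (Homo sapiens) for activation, with a stated time of 24 h (on this read-out higher numbers stand for an effect only at larger amounts of compound and lower numbers for an effect already at smaller amounts), compound 1 `CN1CCN(c2ccc(NCc3ccccc3O)cc2)CC1` is reported as "not active" (no number reported), and compound 2 `Oc1ccccc1CNc1ccc(N2CCCC2)cc1` is likewise reported as "not active" (no number reported). Among the compounds with values here, compound 3 `Oc1ccccc1CNc1ccc(-c2ccc(Cl)cc2)cc1` is the one compound with a figure in this assay, giving 2390 nM, so it stands alone as the sole numbered point, the two other entries being recorded without a figure. Compound 4 `Oc1ccccc1CNc1ccc(-c2ccccc2Cl)cc1` has not yet been measured in this assay. It differs from compound 3 in one place: 2-chlorophenyl in place of 4-chlorophenyl on an aromatic carbon. Within the data shown here, no pair of measured compounds shows this kind of change, so neither direction nor size can be read from the data at hand. Compound 3 at 2390 nM is the only anchor, and the expectation is that the change leaves the result within the scatter or weakens it modestly. For compound 4 the estimated value in this assay is 3500 nM, with an expected range of 900 nM to 14000 nM. The step this implies is expected to be a 1.5-fold higher number from compound 3 to compound 4 (0.17 log units; within the scatter).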

Compound 4, half-maximal effective concentration: "not active" (no number reported)
The entry for compound 4 holds no number; no gap can be computed for the estimate.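

Within the data shown here, compound 4 gives "not active" (no number reported) in this assay and compound 3 gives 2390 nM there, so no step between compound 3 and compound 4 can be read. Nothing shown bears on this result. The compounds shown leave open how large the change from 4-chlorophenyl to 2-chlorophenyl is.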